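Swapping the Benzyl Halogen in a Weak Amide Series

The source may report more compounds than this note shows. Statements on the series, on what has been measured and on what is new or still open speak of the compounds shown alone.

Compound 1 `CC(C)Cc1ccc(C(C)C(=O)NCc2ccc(F)cc2)cc1`: 27000 nM
Compound 2 `CC(C)Cc1ccc(C(C)C(=O)NCc2cccc(C(F)(F)F)c2)cc1`: 28000 nM

Both compounds were tested in an assay on brain for inhibition of Fatty-acid amide hydrolase 1 (Rattus norvegicus), read by scintillation counting, with a stated time of 10 min; a higher number here means a weaker inhibitor, a lower number a stronger inhibitor. Compound 1 gives 27000 nM, and compound 2 gives 28000 nM; the two numbers lie within the scatter of each other, so neither can be said to differ from the other. Compound 3 `CC(C)Cc1ccc(C(C)C(=O)NCc2ccccc2Cl)cc1` has not been measured. It differs from compound 1 by 2-chlorophenyl in place of 4-fluorophenyl on a saturated chain carbon bound to an amide-type nitrogen. For the measured compounds named here, no measured pair shows this change, so its step size is unknown; in this assay no step beyond the scatter is expected in either direction. Compound 3 is therefore expected to give 25000 nM (range 8000 nM to 80000 nM). The expected step is a 1.1-fold lower number from compound 1 to compound 3 (0.03 log units; within the scatter).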

Compound 3, half-maximal inhibitory concentration: 4100 nM
Compound 3: the middle estimate sits 6.1-fold (0.79 log units) above what was measured, and the stated range ends above it.
By their numbers in this assay, from the lowest: compound 3; then compounds 1 and 2 (each within the scatter of the next).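

In this assay, the group on this saturated chain carbon bound to an amide-type nitrogen can change the result: 2-chlorophenyl in place of 4-fluorophenyl gives a 6.6-fold lower number from compound 1 to compound 3 (0.82 log units; beyond the scatter). The two earlier numbers, within the scatter of each other, showed no such sensitivity at this position. No available measurement explains this step.

This one change replaces fluorine with chlorine and also moves the halogen, so the compounds shown cannot separate those two parts. As far as these compounds go, how plain phenyl or a bromine-bearing phenyl ring would compare also remains open.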